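The source may hold more compounds than are shown below. What is called first, only, known or untested is meant among the compounds shown, and "the series" means these compounds.

Compound 3 `COc1cc(-c2nnc(SCC(=O)Nc3ccccc3C)n2N)cc(OC)c1OC` has been tested in a functional assay on HepG2 cells (Homo sapiens) for antiproliferative activity, read by MTT assay, with a stated time of 48 h; on this read-out higher numbers stand for weaker inhibition and lower numbers for stronger inhibition. In this assay compound 3 gives only a limit of the assay, > 100000 nM. Compound 1 `COc1cc(-c2nnc(SCC(=O)c3ccc(Cl)cc3)n2N)cc(OC)c1OC` likewise gives a limit in this assay, > 100000 nM. Compound 2 `COc1cc(-c2nnc(SCC(=O)c3ccc(F)c(F)c3)n2N)cc(OC)c1OC` also gives a limit in this assay, > 100000 nM. All three therefore sit at the limit of > 100000 nM in this assay, at which 3 of the 3 values shown sit, so the steps a step that the two limits leave unreadable from compound 1 to compound 3 and a step that the two limits leave unreadable from compound 2 to compound 3 cannot be read in size or direction. Compound 4 `COc1cc(-c2nnc(SCC(=O)Nc3ccccc3F)n2N)cc(OC)c1OC` differs from compound 3 by fluoro in place of methyl on an aromatic carbon. With every measured step unreadable, nothing in these numbers suggests that this change would lift compound 4 off the limit. The expected step is a number no higher from compound 3 to compound 4 (the limit leaves the size open). Compound 4 is therefore estimated at 100000 nM, with a range from 30000 nM to 300000 nM, and most likely reported again only as a limit.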

Compound 4, half-maximal inhibitory concentration: 18700 nM
For compound 4 the middle estimate is 5.3-fold (0.73 log units) above the measured one; measured number outside the range, below it.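

In this assay, among the compounds shown here, fluoro in place of methyl on the aromatic ring gives the first readable step: an at least 5.3-fold lower number from compound 3 to compound 4 (0.72 log units; beyond the scatter). With (2-fluorophenyl)amino on the carbonyl carbon, two further steps can also be read: an at least 5.3-fold lower number from compound 2 to compound 4 (0.72 log units; beyond the scatter) and an at least 5.3-fold lower number from compound 1 to compound 4 (0.72 log units; beyond the scatter). Compound 4 is the only compound shown that comes off the limit, which holds the other three: the limit of > 100000 nM in this assay, at which 3 of the 4 values shown sit.

The steps among compound 1, compound 2 and compound 3 still cannot be read. Going by these compounds, whether bromo or methoxy at this place would also lift a compound off the limit stays open.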